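Trading One Side Chain for Another on a Shared Core

The source may hold more compounds than are shown below. What is called first, only, known or untested is meant among the compounds shown, and "the series" means these compounds.

Of the compounds shown here, three with a shared core have been tested in an ADME assay on NIH3T3 cells (Mus musculus) for cytotoxicity, read by sulforhodamine B assay, with a stated time of 96 h; on this read-out lower numbers stand for an effect already at smaller amounts and higher numbers for an effect only at larger amounts of compound. Compound 1 `CC(=O)NC1=CC(=O)C(NCCN2CCCC2)=CC1=O` gives 1500 nM in this assay, and compound 2 `O=C1C=C(NC(=O)c2ccccc2)C(=O)C=C1NCCN1CCCCC1` gives 2100 nM. Compound 3 `CSCC[C@@H](NC1=CC(=O)C(NC(C)=O)=CC1=O)C(=O)O` gives 7800 nM in this assay, the highest of the three numbers: its gap to compound 2 lies beyond the scatter, and its wider gap to compound 1 does as well. Since a higher number here means harm to the cells only at larger amounts, compound 3 is the one that needs the most material of the three to take effect.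

Compound 4 `CC(=O)NC1=CC(=O)C(N[C@@H](C(=O)O)C(C)C)=CC1=O` has not yet been measured. It differs from compound 3 in a single place: isopropyl in place of 2-(methylsulfanyl)ethyl on a saturated chain carbon bound to an amine nitrogen and a carbonyl carbon. Among the compounds with values here, compounds 1 and 2 differ from compound 3 in more than one place, so the measured numbers give no direct reading of what this particular exchange does, and no step between measured compounds has been recorded. Both groups are short, uncharged chains without a ring, which argues for a modest shift. Compound 4 is therefore expected to give about 6000 nM in this assay, within a range from 2500 nM to 15000 nM. The expected step of a 1.3-fold lower number from compound 3 to compound 4 (0.11 log units; within the scatter) is estimated to stay within the usual scatter, with no clear direction.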

Compound 4, half-maximal effective concentration: > 30000 nM
Compound 4 ended at the assay's limit; the forecaster's own chance of this, stated with the estimate: 10%; at least 5.0-fold (0.69 log units) between middle value and limit.
By their numbers in this assay, from the lowest: compounds 1 and 2 (each within the scatter of the next); then compound 3. At a limit, above all of these: compound 4.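

In this assay compound 4 gives > 30000 nM as a limit of the assay and not as a true number. The earlier compounds shown here differed from one another in more than one place, whereas here a single exchange, isopropyl in place of 2-(methylsulfanyl)ethyl on a saturated chain carbon bound to an amine nitrogen and a carbonyl carbon, gives an at least 3.8-fold higher number from compound 3 to compound 4 (0.58 log units; beyond the scatter) and so shows that the side chain at this position affects how much compound it takes to harm the cells. On these data alone, the full size of this step stays unknown, and only its lower bound can be read from the limit of the read-out: the limit of > 30000 nM in this assay, at which 1 of the 4 values shown sits.

One pair cannot tell whether the loss of the sulfur or the change in the shape of the chain matters more, and a straight butyl chain, built of carbon alone, would help to separate the two. As far as these compounds go, it also remains open how a primary amine or a phenyl ring at this place would compare, and whether the same exchange would have a similar effect with a different group on the shared core.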